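A few compounds are considered here, and "the series" means these few. Any claim that something is new, unique, unknown or untested is made for them only; others in the source may bear on it.

Of the compounds shown here, two that share one core have so far been measured in an assay on HEK293 cells for positive allosteric modulation of metabotropic glutamate receptor 5 (Homo sapiens), read by FLIPR, with a stated time of 1 h; on this read-out higher numbers stand for an effect only at larger amounts of compound and lower numbers for an effect already at smaller amounts. Compound 1 `O=C1NCCc2nc(C#Cc3cccc(F)c3)sc21` gives 290 nM in this assay. Compound 2 `CCCCN1CCc2nc(C#Cc3ccccc3)sc2C1` gives 110 nM in this assay. For the measured compounds named here, of these two numbers, the one for compound 2 is the lower; its only neighbour is compound 1, whose number lies higher by a margin beyond the scatter, so within this small set compound 2 stands as the more active of the two. The compound not yet measured is compound 3 `CC1CC1C(=O)N1CCc2nc(C#Cc3ccccc3)sc2C1`, which differs from compound 2 in one place: (2-methylcyclopropyl)carbonyl in place of butyl on an amine nitrogen in a ring. Going by the values given here, no step between measured compounds bears on this kind of change, so the expectation rests on the value of compound 2 alone. Because compound 2 already gives 110 nM, compound 3 is expected to land near it, with an expected step of a 1.4-fold lower number from compound 2 to compound 3 (0.14 log units; within the scatter) that leans toward a lower number but may well stay within the scatter. For compound 3 the estimate in this assay is 80 nM, with a range from 15 nM to 400 nM.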

Compound 3, half-maximal effective concentration: 9.4 nM
Estimate against measurement, compound 3: 8.5-fold (0.93 log units) above; the measured number lies below the stated range.
By their numbers in this assay, from the lowest: compound 3; then compound 2; then compound 1.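

At the amine nitrogen in a ring, the reading in this assay depends strongly on the group attached: (2-methylcyclopropyl)carbonyl in place of butyl gives a 12-fold lower number from compound 2 to compound 3 (1.07 log units; beyond the scatter), the first step seen at this position, since the earlier pair differed in more than one place and could not isolate it. The change adds a carbonyl, with one hydrogen-bond acceptor where butyl has none, and a three-membered carbon ring where butyl has no ring, while neither group carries a net charge, so several features change together in this single step. No measurement shown here explains the gain in activity.

The compounds shown leave open whether the carbonyl, the three-membered ring or the methyl on that ring accounts for the step, a question that an acetyl group, an unsubstituted cyclopropylcarbonyl group and a cyclopropylmethyl group on the same nitrogen would help to separate. Going by these compounds, it also remains open how other groups at this nitrogen, such as a benzoyl group, a sulfonamide or a urea, would read.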